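The compounds below may be only part of what the source reports. "The series", "measured", "known", "first", "only" and "open" are said of these compounds alone.

Measured compounds:
- compound 1, `CCCS(=O)(=O)Nc1ccc(Cl)c(C(=O)Nc2cnc3[nH]ncc3c2)c1F`: in an ADME assay on the whole organism (plasma, strain CD-1) for pharmacokinetics, with Mus musculus as the target, at a dose of 30 mg/kg by the oral route (a higher number here means more compound in the circulation at the dose given, a lower number less compound in the circulation), compound 1 gives 147000 ng.h/mL
- compound 2, `CCCS(=O)(=O)Nc1ccc(F)c(C(=O)Nc2cnc3[nH]nc(C)c3c2)c1F`: in this assay compound 2 gives 18300 ng.h/mL
- compound 3, `CCCS(=O)(=O)Nc1ccc(F)c(C(=O)Nc2cnc3[nH]cc(Br)c3c2)c1F`: in this assay compound 3 gives 49000 ng.h/mL

Compound 2 stands lowest of these three numbers. Compound 3 shows a higher value, a gap beyond the usual scatter, and compound 1 shows the highest value of all, a gap far beyond the scatter. These three compounds differ from one another in more than one place, so no single structural change can be tied to the differences between their numbers.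

Compound 4, `CCCS(=O)(=O)Nc1ccc(F)c(C(=O)Nc2cnc3[nH]nc(Br)c3c2)c1F`, is not yet measured. It differs from compound 2 in one place only: bromo in place of methyl on an aromatic carbon. Among the measured compounds shown here, no measured pair shows this change on its own. Compound 3 also carries a bromo group and gives 49000 ng.h/mL, but it differs from compound 2 elsewhere as well, so it cannot settle the direction. The step from compound 2 to compound 4 is therefore expected to be modest, perhaps slightly upward but plausibly within the scatter: a 1.4-fold higher number from compound 2 to compound 4 (0.14 log units; within the scatter). Compound 4 is estimated to give 25000 ng.h/mL, with a range from 9000 ng.h/mL to 70000 ng.h/mL.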

Compound 4, area under the concentration-time curve in the Mus musculus assay: 52500 ng.h/mL
For compound 4 the middle estimate is 2.1-fold (0.32 log units) below the measured one; the measured number falls inside the stated range.
By their numbers in the Mus musculus assay, from the lowest: compound 2; then compounds 3 and 4 (each within the scatter of the next); then compound 1.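

Among the compounds shown here, in the Mus musculus assay, placing bromo in place of methyl on this aromatic carbon of the five-membered ring gives a 2.9-fold higher number from compound 2 to compound 4 (0.46 log units; beyond the scatter), the first reading of this change on its own, as the earlier compounds differed from one another in more than one place. In a physicochemical assay for solubility, read by HPLC, in phosphate buffer, with a stated time of 24 h, at pH 6.5 (a lower number here means a less soluble compound, a higher number a more soluble compound), compound 2 gives 380 ug/mL and compound 4 gives 1 ug/mL so the same change runs in the opposite direction and much further: the measured solubility of compound 2, 380 ug/mL, and of compound 4, 1 ug/mL, a 380-fold lower number (2.58 log units; beyond the scatter) The swap leaves the counts of heavy atoms and of hydrogen-bond donors and acceptors unchanged, so this position responds strongly to a change that those counts do not register, and within this pair the two read-outs move in opposite directions.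

On these data alone, whether another group on this carbon, such as a nitrile or an amine, would keep the higher number in the Mus musculus assay without the drop in the physicochemical assay remains open. For the compounds shown here, also open is whether bromo in place of methyl would give the same two results on a different background, as this single pair is the only direct reading of the change.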